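Nitro to Trifluoromethyl: Expected Cytotoxicity in Breast Cancer Cells

This account rests on a few compounds, and the source may have more. Where it says the series, first, only, none or still open, it means among the compounds named here.

Of the compounds shown here, three built on one shared core have been tested in a functional assay on MCF7 cells (Homo sapiens) for cytotoxicity, read by CCK-8 assay, with a stated time of 24 h; on this read-out lower numbers stand for stronger inhibition and higher numbers for weaker inhibition. Compound 1 `C/C(=C\c1cc(-c2ccccc2)cs1)C(N)=O` gives 2680 nM. Compound 2 `C/C(=C\c1cc(-c2ccc(F)cc2)cs1)C(N)=O`, which carries a fluoro in place of a hydrogen on an aromatic carbon, gives 1440 nM. Compound 3 `C/C(=C\c1cc(-c2ccc([N+](=O)[O-])cc2)cs1)C(N)=O`, which carries a nitro on that same aromatic carbon, gives 1210 nM. Compound 3 thus shows the lowest of the three numbers, although the step of a 1.2-fold lower number from compound 2 to compound 3 (0.08 log units; within the scatter) is within the usual scatter of this assay, while the step of a 2.2-fold lower number from compound 1 to compound 3 (0.35 log units; beyond the scatter) is a modest one beyond it.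

Compound 4 `C/C(=C\c1cc(-c2ccc(C(F)(F)F)cc2)cs1)C(N)=O` differs from compound 3 in one place: trifluoromethyl in place of nitro on an aromatic carbon. Within the data shown here, the steps that bear on this change are the two earlier substitutions on the same aromatic carbon, a 1.9-fold lower number from compound 1 to compound 2 (0.27 log units; within the scatter) and a 2.2-fold lower number from compound 1 to compound 3 (0.35 log units; beyond the scatter). Among the measured compounds shown here, both additions moved the number only a little, and none of the measured compounds carries a trifluoromethyl, so there is no direct measure of that group. The expectation is therefore that compound 4 stays close to compound 3, with an estimated step of a 1.2-fold higher number from compound 3 to compound 4 (0.06 log units; within the scatter). In this assay compound 4 is estimated at 1400 nM, with an expected range from 700 nM to 2900 nM.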

Compound 4, half-maximal inhibitory concentration: 50000 nM
Compound 4: the middle estimate sits 36-fold (1.55 log units) below what was measured; measured number above the stated range.
By their numbers in this assay, from the lowest: compounds 3, 2 and 1 (each within the scatter of the next, the first and the last beyond it); then compound 4.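

Among these compounds, on this aromatic carbon, para to a large group, hydrogen, fluoro and nitro had produced no large step in this assay, so the position looked as if it accepted change easily. Trifluoromethyl ends that picture: in place of nitro it gives a large rise (a 41-fold higher number from compound 3 to compound 4 (1.62 log units; beyond the scatter)), in place of fluoro one of similar size (a 35-fold higher number from compound 2 to compound 4 (1.54 log units; beyond the scatter)), and even in place of plain hydrogen a large one (a 19-fold higher number from compound 1 to compound 4 (1.27 log units; beyond the scatter)), so the position is far more selective about its group than the earlier compounds revealed. Nothing available explains why this one group parts so sharply from the other three.

The compounds shown leave open whether the loss is peculiar to trifluoromethyl or also appears with other groups on this carbon, such as a methyl, a chlorine, a methoxy or a nitrile. They also leave open whether trifluoromethyl on a different carbon of the same six-membered ring would bring a step of this size.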